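Trifluoromethyl on the phenyl of the shared core

A few compounds are considered here, and "the series" means these few. Any claim that something is new, unique, unknown or untested is made for them only; others in the source may bear on it.

Measured so far:
compound 1 `COc1ccc(-c2nc(-c3ccccc3)c(-c3ccc4c(c3)NC(=O)CO4)[nH]2)cc1` — 108%
compound 2 `O=C1COc2ccc(-c3[nH]c(-c4ccccc4)nc3-c3ccccc3)cc2N1` — 105%

In a functional assay on MV4-11 cells (Homo sapiens) for cytotoxicity, read by colorimetric assay and MTT assay, with a stated time of 3 days, tested at 1 uM (on this read-out higher numbers stand for a weaker effect at the one concentration tested and lower numbers for a stronger effect), compound 1 gives 108% and compound 2 gives 105%; the two numbers lie within the scatter of each other, so neither stands apart. Going by the values given here, the only measured step, a number 3 percentage points lower from compound 1 to compound 2 (within the scatter), is a change on an aromatic carbon that left the read-out where it was.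

Compound 3 `O=C1COc2ccc(-c3[nH]c(-c4ccc(C(F)(F)F)cc4)nc3-c3ccccc3)cc2N1` is not yet measured. It differs from compound 2 by trifluoromethyl in place of hydrogen on an aromatic carbon. Among the compounds with values here, no measured step introduces a trifluoromethyl, so nothing bears directly on it; the one step that exists, between compound 1 and compound 2, did not move the number beyond the scatter. On this basis the expectation is no step beyond the scatter in this assay, and the estimated step of a number 5 percentage points lower from compound 2 to compound 3 (within the scatter) reflects that.

For compound 3 the estimated value in this assay is 100%, with a range from 80% to 115%.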

Compound 3, a percentage reported as activity, at one concentration (the size of the read-out at that concentration, not a potency): 111%
The estimate for compound 3 lay 11 percentage points below the measured number; low and high end bracket the measured number.
By their numbers in this assay, from the lowest: compounds 2, 1 and 3 (each within the scatter of the next).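

In this assay, trifluoromethyl on the aromatic carbon para to a large group gives a number 6 percentage points higher from compound 2 to compound 3 (within the scatter), and placing it on that carbon in place of methoxy gives a number 3 percentage points higher from compound 1 to compound 3 (within the scatter). Hydrogen, methoxy and trifluoromethyl at this position, which differ in size and in their atoms, therefore all stay within the scatter, so this change, like the earlier step, shows no separation at the one concentration tested. No supporting data bear on why the read-out stays put.

As far as these compounds go, whether an amine or a carboxylic acid at this carbon would give a step beyond the scatter remains open. Also open, from the compounds shown here alone, is whether changes elsewhere on the shared core, such as at the amide hydrogen or on the other phenyl, would separate these compounds.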